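This account rests on a few compounds, and the source may have more. Where it says the series, first, only, none or still open, it means among the compounds named here.

Three compounds built on one shared core are compared here, differing only in the aromatic group attached to a saturated ring carbon. In an assay on membranes from HEK293 cells for displacement of a labelled ligand from adenosine receptor A2b (Homo sapiens), read by scintillation counting, with a stated time of 30 min, tested at 1 uM (on this read-out higher numbers stand for more inhibition at the one concentration tested (going by the name of the read-out) and lower numbers for less inhibition), compound 1 `COC(=O)C1=C(C)N(C)C(=O)NC1c1ccco1` gives 31%. In this assay compound 2 `COC(=O)C1=C(C)N(C)C(=O)NC1c1cccs1` gives 17%, and compound 3 `COC(=O)C1=C(C)N(C)C(=O)NC1c1ccsc1` gives 26%. The three steps between them are a number 14 percentage points lower from compound 1 to compound 2 (beyond the scatter), a number 5 percentage points lower from compound 1 to compound 3 (within the scatter) and a number 9 percentage points higher from compound 2 to compound 3 (within the scatter). On these numbers compound 3 stands second highest of the three, closest to compound 1 and furthest from compound 2, though both of those gaps lie within the scatter.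

Compound 4 `CCOC(=O)C1=C(C)N(C)C(=O)NC1c1ccsc1` has not yet been measured. It differs from compound 3 by methyl in place of hydrogen on a saturated chain carbon bound to an oxygen next to a carbonyl group. For the measured compounds named here, none of the measured steps touches this part of the molecule: each of them exchanges the aromatic group on the saturated ring carbon, and even the largest of those, from furan-2-yl to thiophen-2-yl, was only modest. Going by the values given here, the ester is untouched in every measured pair, so no measured step speaks to the effect of lengthening it. With so small a change and no evidence of any shift, the expected step is no change at the digits printed from compound 3 to compound 4 (within the scatter), that is, none beyond the scatter. Compound 4 is therefore estimated to give 26% in this assay, with a likely range from 10% to 44%.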

Compound 4, a percentage reported as inhibition, at one concentration (the size of the read-out at that concentration, not a potency): 53%
Compound 4: middle estimate off by 27 percentage points, on the low side; measured number outside the range, above it.
By their numbers in this assay, from the lowest: compounds 2, 3 and 1 (each within the scatter of the next, the first and the last beyond it); then compound 4.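

For the compounds shown here, the ester group stayed the same across the first three compounds, so this is the first look at that end of the molecule. Changing methoxycarbonyl to ethoxycarbonyl, which adds just one carbon, gives a number 27 percentage points higher from compound 3 to compound 4 (beyond the scatter) in this assay, and this is a bigger step than any of the exchanges of the aromatic group, the largest of which was a number 14 percentage points lower from compound 1 to compound 2 (beyond the scatter). So the position is sensitive to this small change, at least with thiophen-3-yl on the saturated ring carbon, although nothing available here accounts for the rise.

From the compounds shown here alone, the rise rests on a single pair, so it remains open whether ethoxycarbonyl would raise the number in the same way with furan-2-yl or thiophen-2-yl in place of thiophen-3-yl. Going by these compounds, it is also open how the read-out at this one concentration would respond to other groups at this position, such as a longer chain like propoxycarbonyl, a branched isopropoxycarbonyl, or a free carboxylic acid.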